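Adding a second methoxy to compound 1

The source may hold more compounds than are shown below. What is called first, only, known or untested is meant among the compounds shown, and "the series" means these compounds.

Compound 1 `COc1ccc(-c2cc(/C=C/C(=O)c3ccc(N)cc3)[nH]n2)cc1` was tested in a functional assay on M14 cells (Homo sapiens) for inhibition, read by sulforhodamine B assay, with a stated time of 48 h (a higher number here means a weaker inhibitor of growth, a lower number a stronger inhibitor of growth), where compound 1 gives 2670 nM. Two related compounds were measured alongside it: compound 2 `COc1ccc(C(=O)/C=C/c2cc(-c3cc(OC)c(OC)c(OC)c3)n[nH]2)cc1OC`, for which compound 2 gives 1840 nM, and compound 3 `COc1ccc(C(=O)/C=C/c2cc(-c3cc(OC)c(OC)c(OC)c3)n[nH]2)cc1`, for which compound 3 gives 2200 nM. Compound 1 has the highest of the three numbers, but its nearest neighbour is compound 3 and its furthest is compound 2, and both gaps lie within the scatter, so no order among them can be claimed.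

Compound 4 `COc1ccc(-c2cc(/C=C/C(=O)c3ccc(N)cc3)[nH]n2)cc1OC` differs from compound 1 in one place: methoxy in place of hydrogen on an aromatic carbon. Within the data shown here, the only measured step that bears on this is a 1.2-fold higher number from compound 2 to compound 3 (0.08 log units; within the scatter), where the same kind of methoxy-for-hydrogen exchange on an aromatic carbon, taken in the opposite direction, stayed within the scatter. A step of similar size, if any, is expected here, so compound 4 is estimated at 2300 nM with a range of 1100 nM to 4800 nM, meaning an expected step of a 1.2-fold lower number from compound 1 to compound 4 (0.06 log units; within the scatter).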

Compound 4, concentration for 50% growth inhibition: 2280 nM
Beside the measured number, compound 4's estimate is 1.0-fold (0.00 log units) above it, within the range that was stated.
By their numbers in this assay, from the lowest: compounds 2, 3, 4 and 1 (each within the scatter of the next).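

Placing methoxy on this aromatic carbon, ortho to a methoxy group and meta to a large group, gave a 1.2-fold lower number from compound 1 to compound 4 (0.07 log units; within the scatter) in this assay, so this position accepts the added group with no shift beyond the scatter. Among these compounds, until now the exchange had been read on only one core, and it now has a reading on a second core that agrees with the first: the same change on two cores in this assay, a 1.2-fold higher number (0.08 log units; within the scatter) from compound 2 to compound 3 and a 1.2-fold higher number (0.07 log units; within the scatter) from compound 4 to compound 1, 1.0-fold (0.01 log units) apart, within the scatter of two such steps. On these two cores, the exchange therefore reads as tolerated and not as a gain.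

The compounds shown leave open whether this carbon responds to any group other than methoxy, such as a hydroxyl, a chlorine or a longer chain like ethoxy. They also leave open whether a larger step in this assay can be reached at this position at all.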